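A few compounds are considered here, and "the series" means these few. Any claim that something is new, unique, unknown or untested is made for them only; others in the source may bear on it.

For the measured compounds named here, in a functional assay on NCI-H1975 cells (Homo sapiens) for cytotoxicity, read by MTT assay, with a stated time of 72 h (a higher number here means a weaker inhibitor, a lower number a stronger inhibitor), compound 1 `O=C(N/N=C/c1cccc([N+](=O)[O-])c1)N1CCc2ncnc(Nc3ccc(F)c(Cl)c3)c2C1` gives 86900 nM as the highest of the two numbers measured so far, and compound 2 `Cc1ccc(/C=N/NC(=O)N2CCc3ncnc(Nc4ccc(F)c(Cl)c4)c3C2)cc1C` stands lower at 6830 nM on that scale. Compound 3 `O=C(N/N=C/c1ccc(F)cc1)N1CCc2ncnc(Nc3ccc(F)c(Cl)c3)c2C1` differs from compound 1 in one place (4-fluorophenyl in place of 3-nitrophenyl on a carbon with a double bond to nitrogen), with 4-fluorophenyl in place of 3-nitrophenyl on a carbon with a double bond to nitrogen. Going by the values given here, only one measured step bears on this, at that same place (a 13-fold lower number from compound 1 to compound 2 (1.10 log units; beyond the scatter)), and it is large and beyond the scatter. A smaller step in the same direction is therefore expected in this assay for this change. The expected step (a 5.8-fold lower number from compound 1 to compound 3 (0.76 log units; beyond the scatter)) rests on that single comparison. The estimated value for compound 3 is 15000 nM (4000 nM to 60000 nM).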

Compound 3, half-maximal inhibitory concentration: 64500 nM
Compound 3: middle estimate off by 4.3-fold (0.63 log units), on the low side; the measured number lies above the stated range.
By their numbers in this assay, from the lowest: compound 2; then compounds 3 and 1 (each within the scatter of the next).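

In this assay, 4-fluorophenyl in place of 3-nitrophenyl on a carbon with a double bond to nitrogen gives a 1.3-fold lower number from compound 1 to compound 3 (0.13 log units; within the scatter), so this change separates the two compounds by no more than the scatter. The earlier gain therefore does not follow from merely removing 3-nitrophenyl: 3,4-dimethylphenyl stands apart here, with a 9.4-fold higher number from compound 2 to compound 3 (0.98 log units; beyond the scatter). Nothing available explains this difference. Going by these compounds, it remains open whether a single methyl group would suffice, and how a phenyl ring carrying an amine or a carboxylic acid would read at this place.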